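A few compounds are considered here, and "the series" means these few. Any claim that something is new, unique, unknown or untested is made for them only; others in the source may bear on it.

Of the compounds shown here, three that share one core have been measured in an in vitro assay on BTI-TN-5B1-4 cells for inhibition of Amine oxidase [flavin-containing] A (Homo sapiens), read by fluorescence; a higher number here means a weaker inhibitor, a lower number a stronger inhibitor. Compound 1 `CCc1ccc(NC(=O)c2cc3ccccc3oc2=O)cc1` gives 15700 nM, compound 2 `CC(C)c1ccc(NC(=O)c2cc3ccccc3oc2=O)cc1` gives 15100 nM, and compound 3 `O=C(Cl)c1ccc(NC(=O)c2cc3ccccc3oc2=O)cc1` gives 9670 nM. Compound 2 stands second highest of these three numbers, nearest to compound 1 and furthest from compound 3, and each gap lies within the scatter: a 1.0-fold lower number from compound 1 to compound 2 (0.02 log units; within the scatter), a 1.6-fold lower number from compound 1 to compound 3 (0.21 log units; within the scatter) and a 1.6-fold lower number from compound 2 to compound 3 (0.19 log units; within the scatter).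

Compound 4 `CS(=O)(=O)c1ccc(NC(=O)c2cc3ccccc3oc2=O)cc1` has not yet been measured. It differs from compound 2 by methylsulfonyl in place of isopropyl on an aromatic carbon. The step that bears most directly on this change swapped the same isopropyl for a different group on the same aromatic carbon, a 1.6-fold lower number from compound 2 to compound 3 (0.19 log units; within the scatter), and stayed within the scatter; the swap starting from ethyl, a 1.6-fold lower number from compound 1 to compound 3 (0.21 log units; within the scatter), did the same. For the measured compounds named here, nothing among the measured compounds points to a larger shift, so the expected step in this assay is a 1.3-fold lower number from compound 2 to compound 4 (0.10 log units; within the scatter), not beyond the scatter. Compound 4 is therefore estimated at 12000 nM, within a range from 5000 nM to 30000 nM.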

Compound 4, half-maximal inhibitory concentration: 9330 nM
Beside the measured number, compound 4's estimate is 1.3-fold (0.11 log units) above it; the range from low to high includes it.
By their numbers in this assay, from the lowest: compounds 4, 3, 2 and 1 (each within the scatter of the next).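

In this assay, methylsulfonyl, which brings two hydrogen-bond acceptors to this aromatic carbon, stays within the scatter of every earlier group: isopropyl (a 1.6-fold lower number from compound 2 to compound 4 (0.21 log units; within the scatter)), ethyl (a 1.7-fold lower number from compound 1 to compound 4 (0.23 log units; within the scatter)) and the chlorine-bearing carbonyl group (a 1.0-fold lower number from compound 3 to compound 4 (0.02 log units; within the scatter)). The earlier compounds shown here showed this only for two small carbon chains and that one carbonyl group, whereas the flat result now also holds for a sulfur-containing group, so across these four compounds no swap at this position has moved the number beyond the scatter. Nothing measured here accounts for this flatness.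

The compounds shown leave open whether an amine, a carboxylic acid or a longer chain on this carbon would give a step beyond the scatter. They also leave open how plain hydrogen here, or any of these groups on another carbon of the ring, would compare.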